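The source may hold more compounds than are shown below. What is called first, only, known or untested is meant among the compounds shown, and "the series" means these compounds.

Measured so far:
compound 1, `CC[C@@H](Nc1c(C#N)c(-c2ccc(-c3cccc(OC)c3)cc2)nc2cnccc12)C(N)=O`: 104 nm/s
compound 2, `CCOc1ccccc1-c1ccc(-c2nc3cncc(Cl)c3c(N[C@H](CC)C(N)=O)c2C#N)cc1`: 17 nm/s

Both numbers come from an ADME assay on Caco-2 cells (Homo sapiens) for permeability, read by LC-MS, in the apical to basolateral direction, with a stated time of 2 h, tested at 2 uM; a higher number here means that the compound crosses the layer faster, a lower number that the compound crosses the layer more slowly. On these two numbers compound 1 holds the higher one, and compound 2, which gives 17 nm/s, sits well below it, beyond the usual scatter of this assay. The two structures differ in more than one place, so no single step can be read from that pair and nothing is said here about its cause.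

Compound 3, `CC[C@@H](Nc1c(C#N)c(-c2ccc(-c3ccccc3F)cc2)nc2cnccc12)C(N)=O`, is not yet measured. Against compound 1 it differs in one place: 2-fluorophenyl in place of 3-methoxyphenyl on an aromatic carbon. A 3-methoxyphenyl leaves and a 2-fluorophenyl enters, on an aromatic carbon that is para to a large group.

For the measured compounds named here, no measured pair shows this change, so the size of its step in this assay is open. The expectation is a step of modest size, if any, lying within the scatter, with the number of compound 3 close to that of compound 1. The estimate for compound 3 is 120 nm/s, with a range from 60 nm/s to 240 nm/s. This estimate means an expected step of a 1.2-fold higher number from compound 1 to compound 3 (0.06 log units; within the scatter) that stays within the scatter.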

Compound 3, apparent permeability: 140 nm/s
Compound 3: the middle estimate sits 1.2-fold (0.07 log units) below what was measured, within the range that was stated.
By their numbers in this assay, from the lowest: compound 2; then compounds 1 and 3 (each within the scatter of the next).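

In this assay, for the compounds shown here, the replacement of 3-methoxyphenyl by 2-fluorophenyl on the aromatic carbon para to a large group gives a 1.3-fold higher number from compound 1 to compound 3 (0.13 log units; within the scatter) and is the first step that can be read at this position. For these two compounds, the exchange of one uncharged aromatic ring of carbon only for another, with the loss of the hydrogen-bond acceptor counted on the 3-methoxyphenyl group, leaves the two numbers within the usual scatter of each other. The data on hand offer no explanation for this result, and nothing separates the contributions of the departing methoxy group and the entering fluorine.

Going by these compounds, both groups compared here are uncharged substituted phenyl rings, so it remains open whether an aminomethyl group or a carboxylic acid on that ring would hold the number in the same region of this assay or move it beyond the scatter. Compound 2 differs from compound 1 and compound 3 in more than one place, so steps to it cannot be read, and the contribution of each of its differences stays unresolved.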